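A Swapped Group on a Sulfonyl Sulfur

A few compounds are considered here, and "the series" means these few. Any claim that something is new, unique, unknown or untested is made for them only; others in the source may bear on it.

Compound 1 `Cc1ccccc1S(=O)(=O)c1ccc(CNC(=O)c2cc3cnccc3[nH]2)cc1` is the starting point here. In an ADME assay on microsomes from liver (Homo sapiens) for metabolic stability, read by LC-MS, with a stated time of 30 min, tested at 1 uM (on this read-out higher numbers stand for a more stable compound and lower numbers for a less stable compound), compound 1 gives 48%. Going by the values given here, only one other compound has a number so far: compound 2 `O=C(NCc1ccc(S(=O)(=O)c2ccccc2)cc1)c1cc2ncccc2s1` gives 81% in this assay. That gap lies beyond the usual scatter of repeated measurements, which leaves compound 1 with the lower of the two numbers.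

Compound 3 `O=C(NCc1ccc(S(=O)(=O)c2cccc(F)c2)cc1)c1cc2cnccc2[nH]1` has not been measured yet. It keeps the core of compound 1 and carries 3-fluorophenyl in place of 2-methylphenyl on a sulfonyl sulfur.

The two measured compounds differ in more than one place, so neither shows directly what this single swap does. The forecast is therefore uncertain. A moderate rise is expected, resting only on the higher number of compound 2 at 81%, which shows that a compound in this small set can score well above compound 1. The estimated change is a number 14 percentage points higher from compound 1 to compound 3 (beyond the scatter) in this assay. For compound 3 the estimated value is 62%, with an expected range of 42% to 82%.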

Compound 3, percent of the compound remaining: 79%
Compound 3: middle estimate off by 17 percentage points, on the low side; the measured number falls inside the stated range.
By their numbers in this assay, from the lowest: compound 1; then compounds 3 and 2 (each within the scatter of the next).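

Going by these compounds alone, compound 3 gives the first clean reading at this position: with the core of compound 1 kept, 3-fluorophenyl in place of 2-methylphenyl on a sulfonyl sulfur gives a number 31 percentage points higher from compound 1 to compound 3 (beyond the scatter) in this assay. The earlier pair differed in more than one place, so it could not tie any change in the percent of compound remaining to this group alone, whereas here the group on the sulfur is the only difference. The swap is also a close one in the simple counts, since both groups have 7 heavy atoms, one six-membered aromatic ring of carbon only, no hydrogen-bond donors or acceptors and no net charge, and no measurement here explains why the number moves so far.

Within the data shown here, the single step removes the methyl and brings in the fluorine together, so it leaves open whether the gain belongs to the loss of one, the arrival of the other, or the changed place on the ring. Groups such as 2-fluorophenyl, 3-methylphenyl or cyclohexyl on the same sulfur would be needed to separate these readings, and how they would score on the core of compound 1 remains unknown.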